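The source may hold more compounds than are shown below. What is called first, only, known or untested is meant among the compounds shown, and "the series" means these compounds.

Compounds measured so far:

Compound 1, `O=C(O)[C@H]1NCC=C[C@@H]1O`, 60%.
Compound 2, `O=C(O)[C@@H]1NC[C@@H](O)[C@H](O)[C@@H]1O`, 0.8%.

In an assay on isolated protein for inhibition of cytosolic endo-beta-N-acetylglucosaminidase (Homo sapiens), tested at 1000 uM (a higher number here means more inhibition at the concentration tested (going by the name of the read-out), a lower number less inhibition), compound 1 gives 60%, while compound 2 gives 0.8%. For the measured compounds named here, compound 2 therefore stands lowest of the two numbers measured, with compound 1 as its only neighbour, a gap that is beyond the scatter of the assay. Going by the values given here, no step between a matched pair of measured compounds exists in this set, so nothing has been learnt directly about how a change in configuration alone moves the read-out.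

Compound 3, `O=C(O)[C@@H]1NC[C@H](O)[C@H](O)[C@H]1O`, has not yet been measured. It differs from compound 2 as follows: the two compounds have the same atoms and bonds and differ only in configuration as drawn: 2 of 4 stereo elements differ; a stereocentre at a saturated ring carbon is drawn R in compound 2 and S in compound 3; a stereocentre at a saturated ring carbon is drawn R in compound 2 and S in compound 3. Among the compounds with values here, with compound 2 already at the floor of the read-out, the only room for a step beyond the scatter lies upward; whether a change of configuration at two ring stereocentres is enough to reach it cannot be told from compound 1 and compound 2 alone, since neither shares this relation with the other.

Compound 3 is expected to give 15%, within a range from 0% to 55%. The step this estimate means is a number 14.2 percentage points higher from compound 2 to compound 3 (beyond the scatter), an expected modest rise that may or may not clear the scatter.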

Compound 3, a percentage reported as inhibition, at one concentration (the size of the read-out at that concentration, not a potency): 39%
Compound 3: the middle estimate sits 24 percentage points below what was measured, and the stated range covers the measured number.
By their numbers in this assay, from the lowest: compound 2; then compound 3; then compound 1.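

In this assay, for the compounds shown here, the change of configuration gives a number 38.2 percentage points higher from compound 2 to compound 3 (beyond the scatter), the first matched comparison in this set, and it shows that the read-out responds to the arrangement at two saturated ring carbons even though no atom or bond changes. Compound 3 carries the same groups as compound 2. The near absence of inhibition seen with compound 2 is therefore not shared by every compound that carries those groups. The step can be assigned to stereochemistry, and to nothing else in the structures, because of one plain fact about this pair: the fact that compounds 2 and 3 differ only in the configuration as drawn

The two stereocentres change together, so the compounds shown do not tell whether one of them carries most of the step or whether both are needed, and a read-out at a single concentration gives no potency for either compound. They also leave open how the read-out would respond if a hydroxymethyl group or a primary amide took the place of the carboxylic acid that all three compounds share.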